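Replacing a basic side chain with a benzimidazole amine

The source may report more compounds than this note shows. Statements on the series, on what has been measured and on what is new or still open speak of the compounds shown alone.

Three compounds share one core and differ only in the group attached to one aromatic carbon. Compound 1 `O=C(NCC1(c2nc(-c3ccccc3)cs2)CCOCC1)c1ccc(CN2CCCCC2)cc1` carries a (piperidin-1-yl)methyl group there. In a physicochemical assay for solubility, read by chemiluminescence, in phosphate buffer, measured as kinetic solubility, at pH 7.4 (a lower number here means a less soluble compound, a higher number a more soluble compound), compound 1 gives >= 396000 nM, which is a limit of the assay rather than a number (the limit of >= 396000 nM in this assay, at which 1 of the 3 values shown sits). Compound 2 `O=C(NCC1(c2nc(-c3ccccc3)cs2)CCOCC1)c1ccc(Nc2nncs2)cc1` carries a (1,3,4-thiadiazol-2-yl)amino group and in this assay compound 2 gives 29000 nM. Compound 3 `O=C(NCC1(c2nc(-c3ccccc3)cs2)CCOCC1)c1ccc(-n2cncn2)cc1` carries a 1H-1,2,4-triazol-1-yl group and in this assay compound 3 gives 191000 nM. Both replacements lowered the number: an at least 13-fold lower number from compound 1 to compound 2 (1.13 log units; beyond the scatter) and an at least 2.0-fold lower number from compound 1 to compound 3 (0.31 log units; beyond the scatter), with a 6.6-fold higher number from compound 2 to compound 3 (0.82 log units; beyond the scatter) between them.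

Compound 4 `Cn1c(Nc2ccc(C(=O)NCC3(c4nc(-c5ccccc5)cs4)CCOCC3)cc2)nc2ccccc21` has not yet been measured. It differs from compound 1 as follows ((1-methyl-1H-benzimidazol-2-yl)amino in place of (piperidin-1-yl)methyl on an aromatic carbon). Within the data shown here, the closest measured step is the one to compound 2, where an aromatic heterocycle joined through an amino group also replaced the (piperidin-1-yl)methyl group, and that step was large. Compound 4 brings in an amino-linked aromatic group again, larger than in compound 2, so a large drop is expected: an at least 26-fold lower number from compound 1 to compound 4 (1.42 log units; beyond the scatter). The expected value for compound 4 in this assay is 15000 nM, with a range of 3000 nM to 80000 nM.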

Compound 4, solubility: 10000 nM
Compound 4: middle estimate off by 1.5-fold (0.18 log units), on the high side; low and high end bracket the measured number.
By their numbers in this assay, from the lowest: compound 4; then compound 2; then compound 3. At a limit, above all of these: compound 1.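

In this assay, keeping the amino link and changing only the ring on it gives a 2.9-fold lower number from compound 2 to compound 4 (0.46 log units; beyond the scatter), so the group on that nitrogen matters at this position and not just the removal of (piperidin-1-yl)methyl. Against the triazole, the change gives a 19-fold lower number from compound 3 to compound 4 (1.28 log units; beyond the scatter), which puts compound 4 lowest of the measured compounds and, like compound 2, under compound 3. The drop from the piperidine compound is an at least 39-fold lower number from compound 1 to compound 4 (1.59 log units; beyond the scatter), but compound 1 stands at a limit of the assay rather than at a number, so this step gives only a minimum size: the limit of >= 396000 nM in this assay, at which 1 of the 4 values shown sits.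

The compounds shown leave open whether the low numbers of compound 2 and compound 4 follow from the amino link, from the aromatic ring on it, or from the loss of the piperidine ring, as each replacement changes these together. A (morpholin-4-yl)methyl group, a plain amino group or a phenylamino group on the same aromatic carbon would help pull these apart, and a (1-methyl-1H-benzimidazol-2-yl) group joined without the amino link would test that link directly.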